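Acid dissociation across substituent changes at one aromatic carbon

A few compounds are considered here, and "the series" means these few. Any claim that something is new, unique, unknown or untested is made for them only; others in the source may bear on it.

Of the compounds shown here, three sharing one core have been measured in a physicochemical assay for acid dissociation. Compound 1 `Fc1ccc(Cc2ccc3c(NCCCNCc4ccco4)ccnc3c2)cc1` gives 9.47 in this assay. Compound 2 `CC(C)(C)c1ccc(-c2ccc3c(NCCCNCc4ccco4)ccnc3c2)cc1` gives 9.47. Compound 3 `CCC(CC)c1ccc2c(NCCCNCc3ccco3)ccnc2c1` gives 9.47. Compound 3 thus stands level with compounds 1 and 2 at the digits shown: the steps of no change at the digits printed from compound 1 to compound 3 (within the scatter) and no change at the digits printed from compound 2 to compound 3 (within the scatter) both fall within the scatter, as does no change at the digits printed from compound 1 to compound 2 (within the scatter).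

The next compound, compound 4 `COc1ccc(-c2ccc3c(NCCCNCc4ccco4)ccnc3c2)cc1`, is not yet measured. Relative to compound 3 the change is 4-methoxyphenyl in place of pentan-3-yl on an aromatic carbon. The three measured steps all concern the same position and exchange groups of quite different makeup, a 4-fluorobenzyl, a 4-(tert-butyl)phenyl and a pentan-3-yl, without moving the acid dissociation constant beyond the scatter. Those steps bear directly on the present one, since a 4-methoxyphenyl enters at the same aromatic carbon. No step beyond the scatter is therefore expected in this assay. The step expected here is no change at the digits printed from compound 3 to compound 4 (within the scatter). Compound 4 is estimated at 9.47, within a range from 9.2 to 9.75.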

Compound 4, acid dissociation constant: 9.47
The estimate for compound 4 equals the measured number at the digits printed; the range from low to high includes it.
By their numbers in this assay, from the lowest: compounds 1, 2, 3 and 4 (each within the scatter of the next).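

Going by these compounds alone, the 4-methoxyphenyl is the first group at this aromatic carbon to carry an oxygen and a hydrogen-bond acceptor, and in this assay its arrival against pentan-3-yl gives no change at the digits printed from compound 3 to compound 4 (within the scatter). The same holds for two further comparisons: methoxy in place of tert-butyl on an aromatic carbon gives no change at the digits printed from compound 2 to compound 4 (within the scatter), and 4-methoxyphenyl in place of 4-fluorobenzyl gives no change at the digits printed from compound 1 to compound 4 (within the scatter). The range of groups at this position exchanged without a step beyond the scatter therefore now extends to an oxygen-bearing substituent, but no information on hand accounts for this level read-out.

Still open, from the compounds shown here alone, is whether a group of another kind at this aromatic carbon, such as a carboxylic acid, a dimethylamino group or a pyridine ring, would also leave the acid dissociation constant within the scatter. All four compounds keep the rest of the shared core unchanged, so the series says nothing about a change elsewhere, such as a longer chain between the two amine nitrogens.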